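A few compounds are considered here, and "the series" means these few. Any claim that something is new, unique, unknown or untested is made for them only; others in the source may bear on it.

Compound 1, `Brc1ccc(CSc2nnc(-c3ccncc3)n2-c2ccccc2)cc1`, gives 12900 nM in a functional assay on HepG2 cells (Homo sapiens) for inhibition, read by MTT assay, with a stated time of 48 h; a higher number here means a weaker inhibitor, a lower number a stronger inhibitor. Compound 2, `c1ccc(CSc2nnc(-c3ccncc3)n2-c2ccccc2)cc1`, gives 12900 nM in this assay. Compound 3, `O=C(CSc1nnc(-c2ccncc2)n1-c1ccccc1)N/N=C/c1ccc(Cl)cc1`, gives 11000 nM in this assay.

Among the three measured numbers, compound 3 has the lowest, but its gap to compound 1 and its gap to compound 2 both lie within the scatter, so the three compounds cannot be ranked on these data. Compound 4, `O=C(CSc1nnc(-c2ccncc2)n1-c1ccccc1)N/N=C/c1cc(Br)cc(Br)c1O`, is not yet measured. It differs from compound 3 in one place: 3,5-dibromo-2-hydroxyphenyl in place of 4-chlorophenyl on a carbon with a double bond to nitrogen. Going by the values given here, the only measured step that bears on this is the one on the benzyl ring, no change at the digits printed from compound 1 to compound 2 (within the scatter), where swapping hydrogen for bromo on an aromatic carbon left the number unchanged. Among the compounds with values here, no measured step covers a hydroxyl group entering, and none covers two bromines entering at once, so the step in this assay is uncertain. Given the flat step from compound 1 to compound 2, the step of a 1.2-fold lower number from compound 3 to compound 4 (0.09 log units; within the scatter) is expected to stay within or near the scatter. Compound 4 is therefore expected to give about 9000 nM, with a range from 3500 nM to 23000 nM.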

Compound 4, half-maximal inhibitory concentration: 7590 nM
Estimate against measurement, compound 4: 1.2-fold (0.07 log units) above; the range from low to high includes it.
By their numbers in this assay, from the lowest: compounds 4, 3, 1 and 2 (each within the scatter of the next).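

In this assay, 3,5-dibromo-2-hydroxyphenyl in place of 4-chlorophenyl on a carbon with a double bond to nitrogen gives a 1.4-fold lower number from compound 3 to compound 4 (0.16 log units; within the scatter). This is the first step shown at this position, and it shows that a change of the whole aryl group there, which brings in a hydroxyl group and two bromines and removes the chlorine, stays within the scatter. No measurement of any property bears on this result.

The hydroxyl group and the two bromines enter together, so what each contributes alone cannot be read from these compounds. Also open, as far as these compounds go, is whether an amine or a carboxylic acid on this aryl group, or a longer chain in its place, would move the number beyond the scatter.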